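Swapping One Pyridine for Another on the Shared Core

A few compounds are considered here, and "the series" means these few. Any claim that something is new, unique, unknown or untested is made for them only; others in the source may bear on it.

Compound 1, `O=C(O)Cc1sc(C(c2ccc(F)cc2)c2ccc(F)cc2)nc1-c1cn[nH]c1`: 220 nM
Compound 2, `O=C(O)Cc1sc(C(c2ccc(F)cc2)c2ccc(F)cc2)nc1-c1ccnc(F)c1`: 4.7 nM

In an in vitro functional assay on HEK285-7 cells for antagonist activity at prostaglandin D2 receptor 2 (Homo sapiens), read by BRET and beta-arrestin recruitment (a lower number here means a stronger inhibitor, a higher number a weaker inhibitor), compound 2 gives 4.7 nM, the lowest of the two numbers measured. Among the measured compounds shown here, the only step known so far, a 47-fold lower number from compound 1 to compound 2 (1.67 log units; beyond the scatter), was large. Compound 3, `Cc1cc(-c2nc(C(c3ccc(F)cc3)c3ccc(F)cc3)sc2CC(=O)O)cnc1N`, changes the same position again: 6-amino-5-methylpyridin-3-yl in place of 2-fluoropyridin-4-yl on an aromatic carbon. For the measured compounds named here, the one measured step swapped a different pair of groups, so it only shows that this position can move the number strongly. A moderate weakening is expected, a 3.2-fold higher number from compound 2 to compound 3 (0.50 log units; beyond the scatter). Compound 3 is estimated at 15 nM, with a range from 3 nM to 80 nM.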

Compound 3, half-maximal inhibitory concentration: > 100000 nM
Compound 3: only a limit was reported; the forecaster's own chance of this, stated with the estimate: 2%; at least 6600-fold (3.82 log units) between middle value and limit.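

The result for compound 3 is a limit of the assay, not a number: the limit of > 100000 nM in this assay, at which 1 of the 3 values shown sits. Replacing 2-fluoropyridin-4-yl with 6-amino-5-methylpyridin-3-yl gives an at least 21000-fold higher number from compound 2 to compound 3 (4.32 log units; beyond the scatter), while replacing 1H-pyrazol-4-yl with it gives an at least 450-fold higher number from compound 1 to compound 3 (2.65 log units; beyond the scatter). So a pyridine ring at this position does not by itself preserve inhibition, and this change moves the number much further than the earlier step did.

Which part of the new group matters stays open: a 5-methylpyridin-3-yl group, without the amine, or a 6-aminopyridin-3-yl group, without the methyl, could separate the two.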